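The compounds below may be only part of what the source reports. "The series", "measured", "known", "first", "only" and "open" are said of these compounds alone.

Compound 2 `CCOC(=O)C1=Cc2ccccc2OC1(OCc1cc(-c2ccc3ccccc3c2)no1)C(F)(F)F` carries a naphthalen-2-yl group and an ethoxycarbonyl group. In a functional assay on HeLa cells (Homo sapiens) for inhibition, read by MTT assay, with a stated time of 24 h (on this read-out lower numbers stand for stronger inhibition and higher numbers for weaker inhibition), compound 2 gives only a limit, > 150000 nM. Compound 1 `CCOC(=O)C1=Cc2ccccc2OC1(OCc1cc(-c2ccc(F)cc2F)no1)C(F)(F)F` differs from compound 2 by 2,4-difluorophenyl in place of naphthalen-2-yl on an aromatic carbon. In this assay compound 1 again gives only a limit, > 150000 nM. The step that the two limits leave unreadable from compound 2 to compound 1 therefore cannot be sized. Compound 3 `O=C(O)C1=Cc2ccccc2OC1(OCc1cc(-c2ccc3ccccc3c2)no1)C(F)(F)F` differs from compound 2 by hydrogen in place of ethyl on an oxygen next to a carbonyl group. In this assay compound 3 likewise gives only a limit, > 150000 nM, so the step that the two limits leave unreadable from compound 2 to compound 3 also cannot be sized. Compound 4 `O=C(O)C1=Cc2ccccc2OC1(OCc1cc(-c2ccc(F)cc2F)no1)C(F)(F)F` has not yet been measured; it differs from compound 3 by 2,4-difluorophenyl in place of naphthalen-2-yl on an aromatic carbon, the same change that turns compound 2 into compound 1, made at the same place. For the measured compounds named here, because every value so far sits at the limit (the limit of > 150000 nM in this assay, at which 3 of the 3 values shown sit), compound 4 is expected to give about 200000 nM. The expected step is a step that the limit leaves unreadable from compound 3 to compound 4, resting only on the three limits seen.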

Compound 4, half-maximal inhibitory concentration: > 150000 nM
Compound 4: no number, only a limit (the forecaster's own chance of this, stated with the estimate: 90%); the middle value lies beyond the limit too.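

Compound 4 gives only a limit, as do compound 1 and compound 3, so neither step to compound 4 can be read: the limit of > 150000 nM in this assay, at which 4 of the 4 values shown sit.

The compounds shown leave open whether any change at these two places would give a measurable value in this assay.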